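Swapping a chlorinated ring for a methoxy-bearing one

The source may hold more compounds than are shown below. What is called first, only, known or untested is meant among the compounds shown, and "the series" means these compounds.

Measured so far:
- compound 1, `Fc1ccc(N2CCN(CCCCCOc3ccc4c(c3)CCC4)CC2)cc1`: 71%
- compound 2, `Clc1cccc(N2CCN(CCCCOc3ccc4c(c3)CCC4)CC2)c1`: 0%
- compound 3, `Clc1cc(Cl)cc(N2CCN(CCCOc3ccc4c(c3)CCC4)CC2)c1`: 0%

All three compounds were tested in a functional assay on the whole organism for inhibition, with Mus musculus as the target, at a dose of 25 mg/kg by the oral route; on this read-out higher numbers stand for more inhibition at the one dose given (going by the name of the read-out) and lower numbers for less inhibition. Compound 1 gives 71% in this assay, while compound 2 gives 0% and compound 3 gives 0%. Compound 2 thus sits level with compound 3, the two together forming the lowest pair of the three numbers, and compound 1 stands a long way higher, well beyond the scatter.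

The next compound, compound 4 with structure `COc1ccccc1N1CCN(CCCCOc2ccc3c(c2)CCC3)CC1`, is built from compound 2 by one change: 2-methoxyphenyl in place of 3-chlorophenyl on an amine nitrogen in a ring. The rest of the shared core, including the four-carbon chain to the oxygen, is kept.

No comparison of this exact kind exists among the measured compounds, so the size of the step is open. Compound 2 starts at the floor, and the only direction available is upward; compound 1 shows that a different aryl group on this nitrogen can carry the read-out far higher. The expected step from compound 2 to compound 4 is therefore a number 25 percentage points higher from compound 2 to compound 4 (beyond the scatter), an upward move of uncertain size. Compound 4 is estimated at 25%, within a range from 0% to 65%, in this assay.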

Compound 4, a percentage reported as inhibition, in the whole organism at one dose (the size of the read-out at that dose, not a potency): 42%
The estimate for compound 4 lay 17 percentage points below the measured number, and the stated range covers the measured number.
By their numbers in this assay, from the lowest: compounds 2 and 3 (each within the scatter of the next); then compound 4; then compound 1.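

In this assay, putting 2-methoxyphenyl in place of 3-chlorophenyl on the ring amine nitrogen, with the rest of the structure unchanged, gives a number 42 percentage points higher from compound 2 to compound 4 (beyond the scatter). This is the first pair shown that differs in one place only, so it is the first direct sign that the aryl group on this nitrogen can by itself lift a compound off the zero seen for compound 2 at 0%. The data shown offer no measurement that explains why this swap has an effect of this size.

The compounds shown leave open whether the gain belongs to the methoxy group itself or to where it sits on the phenyl ring, and a 3-methoxyphenyl or 2-chlorophenyl group on the same nitrogen would separate those two readings. Also open, from the compounds shown here alone, is whether 2-methoxyphenyl would hold this gain on a shorter or longer chain, and how the result would look at other doses, as a single dose shows the size of the effect and not a potency.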